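This account rests on a few compounds, and the source may have more. Where it says the series, first, only, none or still open, it means among the compounds named here.

Measured compounds:
Compound 1, `NCc1ccc(C(=O)Nc2ccncc2F)cc1-c1cccc(C(=O)OCC2CCCCO2)c1`, in an assay on isolated protein for inhibition of Rho-associated protein kinase 2 (Homo sapiens), read by radiometric assay (on this read-out lower numbers stand for stronger inhibition and higher numbers for weaker inhibition), gives 12 nM.
Compound 2, `CCOC(=O)c1cccc(-c2cc(C(=O)Nc3ccncc3)ccc2CN)c1`, gives in this assay only a limit, < 1 nM.

Among the compounds with values here, compound 1 thus holds the only definite number in this assay. For compound 2 the read-out stops at the limit of < 1 nM in this assay, at which 1 of the 2 values shown sits, a limit and not a number. Within the data shown here, no pair of measured compounds differs in a single place, so no measured step is available to set the size of any change.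

Compound 3, `NCc1ccc(C(=O)Nc2ccncc2F)cc1-c1cccc(C(=O)OCC2CCCC2)c1`, differs from compound 1 by cyclopentyl in place of oxan-2-yl on a saturated chain carbon bound to an oxygen next to a carbonyl group. Among the measured compounds shown here, with no measured step to go by, the change is expected to produce no shift beyond the usual scatter of repeated measurements, in either direction. Compound 3 is therefore expected to give 12 nM, within a range from 4 nM to 35 nM. That expectation amounts to no change at the digits printed from compound 1 to compound 3 (within the scatter).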

Compound 3, half-maximal inhibitory concentration: 13 nM
Compound 3: the middle estimate sits 1.1-fold (0.03 log units) below what was measured; low and high end bracket the measured number.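

In this assay, cyclopentyl in place of oxan-2-yl on a saturated chain carbon bound to an oxygen next to a carbonyl group gives a 1.1-fold higher number from compound 1 to compound 3 (0.03 log units; within the scatter). Within the data shown here, as the only measured step at this place, it shows that going from a six-membered ring with one hetero atom to a five-membered ring of carbon only, and losing the one hydrogen-bond acceptor, leaves the read-out within the scatter. The data shown offer no measured property that would account for this result.

On these data alone, whether an amine, a carboxylic acid or a longer chain at this place would also leave the read-out within the scatter remains open. As far as these compounds go, how compound 2 relates to compound 1 or compound 3 also stays open, since it differs from each of them in more than one place.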